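Trading phenyl for piperidin-1-yl on a growth inhibitor

The compounds below may be only part of what the source reports. "The series", "measured", "known", "first", "only" and "open" are said of these compounds alone.

Compound 1 `O=C1NC(=S)S/C1=C\c1cc(Br)ccc1OCc1ccccc1` and compound 2 `O=C1NC(=S)S/C1=C\c1cc(-c2ccccc2)ccc1OCc1ccccc1` share one core and differ in a single group. In a functional assay on A549 cells (Homo sapiens) for inhibition, read by sulforhodamine B assay (a lower number here means a stronger inhibitor of growth, a higher number a weaker inhibitor of growth), compound 1 gives 7000 nM, and compound 2 gives 4000 nM. With only these two numbers, compound 2 has no clear rank, as its value lies within the usual scatter of the value for compound 1.

The next compound is compound 3 `O=C1NC(=S)S/C1=C\c1cc(N2CCCCC2)ccc1OCc1ccccc1`, which carries piperidin-1-yl in place of phenyl on an aromatic carbon. For the measured compounds named here, one measured step bears on this change, and it concerns the same carbon: a 1.8-fold lower number from compound 1 to compound 2 (0.24 log units; within the scatter), with phenyl in place of bromo. Going by the values given here, this single step is a thin guide, and no compound measured so far has a non-aromatic ring at that carbon. Even so, the only exchange seen there stayed within the scatter, so no clear shift is expected in this assay. The expected result is a 1.3-fold higher number from compound 2 to compound 3 (0.10 log units; within the scatter), which is no real step beyond the scatter. In this assay the estimate for compound 3 is 5000 nM, with an expected range from 2000 nM to 13000 nM.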

Compound 3, concentration for 50% growth inhibition: 3000 nM
For compound 3 the middle estimate is 1.7-fold (0.22 log units) above the measured one; measured number inside the range.
By their numbers in this assay, from the lowest: compounds 3, 2 and 1 (each within the scatter of the next, the first and the last beyond it).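

In this assay, the carbon para to the benzyloxy group tolerates a non-aromatic ring with a nitrogen in it as well as an all-carbon aromatic one: a 1.3-fold lower number from compound 2 to compound 3 (0.12 log units; within the scatter) is the step for piperidin-1-yl in place of phenyl, so swapping one six-membered ring for the other makes no clear difference here. For the compounds shown here, the comparison with the bromo group gives the first step at this carbon to clear the scatter, as a 2.3-fold lower number from compound 1 to compound 3 (0.37 log units; beyond the scatter) is the change for piperidin-1-yl in place of bromo, although this gain is modest and compound 2 lies within the scatter of both compound 1 and compound 3. Nothing available explains these small differences or connects them to any property of the groups.

On these data alone, it remains open how a morpholin-4-yl ring, a carboxylic acid or a longer alkyl chain on this same carbon would behave in this assay. All three compounds also keep the benzyloxy group and the shared core unchanged, so the contribution of those parts to growth inhibition cannot be judged from them.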